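The source may hold more compounds than are shown below. What is called first, only, known or untested is meant among the compounds shown, and "the series" means these compounds.

For the measured compounds named here, in a functional assay on KB cells (Homo sapiens) for antiproliferative activity, read by colorimetric assay and MTT assay (on this read-out lower numbers stand for stronger inhibition and higher numbers for weaker inhibition), two related compounds have numbers so far. Compound 1 `O=S(=O)(Nc1cc(Cl)cc2cc[nH]c12)c1ccc(Cl)cc1` gives 9.1 ug/mL and compound 2 `O=[N+]([O-])c1ccc(S(=O)(=O)Nc2cccc3cc[nH]c23)cc1` gives 15 ug/mL in this test. These two values lie within the usual scatter of repeated measurements, so compound 2 stands level with compound 1 and the data cannot rank them.

Compound 3 `O=[N+]([O-])c1ccc(S(=O)(=O)Nc2cc(Cl)cc3cc[nH]c23)cc1` is compound 2 with a single change, chloro in place of hydrogen on an aromatic carbon of the shared core. Going by the values given here, no measured pair of compounds differs by this change alone, so its effect has not been seen directly. Among the compounds with values here, the only guide is how closely the values sit, with compound 1 at 9.1 ug/mL within the scatter of compound 2. On that thin evidence, no step beyond the scatter is expected in this assay, in either direction. The expected step is a 1.4-fold lower number from compound 2 to compound 3 (0.13 log units; within the scatter), which is small enough to vanish into the noise of the measurement. Compound 3 is estimated to give 11 ug/mL, with a likely range from 4.5 ug/mL to 27 ug/mL.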

Compound 3, half-maximal inhibitory concentration: 12 ug/mL
Beside the measured number, compound 3's estimate is 1.1-fold (0.04 log units) below it, and the stated range covers the measured number.
By their numbers in this assay, from the lowest: compounds 1, 3 and 2 (each within the scatter of the next).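

In this assay, for the compounds shown here, the step of a 1.3-fold lower number from compound 2 to compound 3 (0.10 log units; within the scatter) gives the first direct look at chloro in place of hydrogen on this aromatic carbon of the shared core, and it stays within the scatter, so at this position the two cannot be told apart by this test. The new compound also creates a second matched pair, with nitro in place of chloro on an aromatic carbon elsewhere in the structure, and the step of a 1.3-fold higher number from compound 1 to compound 3 (0.12 log units; within the scatter) likewise stays within the scatter, so neither single change has a measurable effect on this read-out. Nothing available explains why these changes leave the numbers so close.

Going by these compounds, it remains open whether a different group on the same aromatic carbon, such as an amine, a carboxylic acid or a longer carbon chain, would produce a step beyond the scatter. With every step shown lying within the scatter, these compounds also cannot say which part of the structure, if any, governs the activity against these cells.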